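The compounds below may be only part of what the source reports. "The series", "measured", "known", "first", "only" and "open" are said of these compounds alone.

Compound 1 `Cc1ccc(S(=O)(=O)c2nc3ccccc3nc2Nc2ccc(F)cc2)cc1` is the starting point: in a functional assay on HL-60 cells (Homo sapiens) for cytotoxicity, read by MTT assay, with a stated time of 72 h (on this read-out higher numbers stand for weaker inhibition and lower numbers for stronger inhibition), compound 1 gives 5100 nM. Compound 2 `Cc1ccc(S(=O)(=O)c2nc3ccccc3nc2Nc2ccc(Cl)cc2)cc1` differs from it in a single place, (chloro in place of fluoro on an aromatic carbon), and in this assay compound 2 gives 17500 nM, which is a 3.4-fold higher number from compound 1 to compound 2 (0.54 log units; beyond the scatter). Compound 3 `O=S(=O)(c1ccc(Br)cc1)c1nc2ccccc2nc1Nc1ccc(F)cc1` differs from compound 1 elsewhere, on the other ring, (bromo in place of methyl on an aromatic carbon), and in this assay compound 3 gives 260 nM, which is a 20-fold lower number from compound 1 to compound 3 (1.29 log units; beyond the scatter). Among these three, compound 3 carries the lowest number.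

Compound 4 `O=S(=O)(c1ccc(Br)cc1)c1nc2ccccc2nc1Nc1ccc(Cl)cc1` has not yet been measured in this assay. It differs from compound 3 in one place: chloro in place of fluoro on an aromatic carbon. This is the same kind of change that turned compound 1 into compound 2, at a place described in exactly the same words, while the cores of compound 3 and compound 1 differ as already described. If the change repeats its earlier effect, compound 4 is expected to sit a 3.3-fold higher number from compound 3 to compound 4 (0.51 log units; beyond the scatter), an expectation that rests on a 3.4-fold higher number from compound 1 to compound 2 (0.54 log units; beyond the scatter). Compound 4 is therefore estimated at 850 nM in this assay, with a likely range from 300 nM to 2500 nM.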

Compound 4, half-maximal inhibitory concentration: 16400 nM
The estimate for compound 4 lay 19-fold (1.29 log units) below the measured number; measured number above the stated range.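

In this assay the swap of fluoro for chloro keeps its direction on the second core, giving a 63-fold higher number from compound 3 to compound 4 (1.80 log units; beyond the scatter), but its size does not carry over: the same change on two cores in this assay, a 3.4-fold higher number (0.54 log units; beyond the scatter) from compound 1 to compound 2 and a 63-fold higher number (1.80 log units; beyond the scatter) from compound 3 to compound 4, 18-fold (1.26 log units) apart, beyond the scatter of two such steps

Read the other way, the swap of methyl for bromo on the chloro compounds gives a 1.1-fold lower number from compound 2 to compound 4 (0.03 log units; within the scatter), so the large step seen on the fluoro compounds does not repeat: the same change on two cores in this assay, a 20-fold lower number (1.29 log units; beyond the scatter) from compound 1 to compound 3 and a 1.1-fold lower number (0.03 log units; within the scatter) from compound 2 to compound 4, 18-fold (1.26 log units) apart, beyond the scatter of two such steps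

The two changes therefore do not act independently in these four compounds: only compound 3 combines bromo with fluoro, and it carries the lowest number, but two pairs do not show why, nor how either change would behave on another core.

Going by these compounds, it remains open whether the low number of compound 3 depends on this exact pairing of groups, or whether iodo in place of bromo would behave in the same way. Equally open, on these data alone, is what a methoxy or trifluoromethyl group would do in place of the fluoro of compound 3.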